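This account rests on a few compounds, and the source may have more. Where it says the series, first, only, none or still open, it means among the compounds named here.

Measured in a functional assay on MDA-MB-453 cells (Homo sapiens) for antiproliferative activity, read by MTT assay, with a stated time of 72 h; on this read-out higher numbers stand for weaker inhibition and lower numbers for stronger inhibition:
- Compound 1 `O=c1oc2cc(O)ccc2cc1-c1ccc(O)c(F)c1`: > 100000 nM (a limit of the assay, not a number)
- Compound 2 `CCc1c(-c2ccc(O)c(F)c2)c(=O)oc2cc(O)ccc12`: 39800 nM

Among the compounds with values here, compound 2 holds the only true number so far. Within the data shown here, the one measured step is an at least 2.5-fold lower number from compound 1 to compound 2 (0.40 log units; beyond the scatter), with ethyl in place of hydrogen on an aromatic carbon. That step is open-ended, resting on (the limit of > 100000 nM in this assay, at which 1 of the 2 values shown sits).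

Compound 3 `O=c1oc2cc(O)ccc2c(-c2ccc(O)c(F)c2)c1-c1ccc(O)c(F)c1` carries 3-fluoro-4-hydroxyphenyl in place of ethyl on that same aromatic carbon, opposite the ring oxygen: 3-fluoro-4-hydroxyphenyl in place of ethyl on an aromatic carbon. The measured step, an at least 2.5-fold lower number from compound 1 to compound 2 (0.40 log units; beyond the scatter), shows a change on filling this carbon, but it says little about exchanging one group there for another. No clear shift beyond the scatter is therefore expected, and a limit remains possible. The expected change is a 1.3-fold lower number from compound 2 to compound 3 (0.12 log units; within the scatter). For compound 3 the estimated value is 30000 nM, with an expected range of 9000 nM to 100000 nM.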

Compound 3, half-maximal inhibitory concentration: 31700 nM
The estimate for compound 3 lay 1.1-fold (0.02 log units) below the measured number; the range from low to high includes it.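

In this assay, 3-fluoro-4-hydroxyphenyl in place of ethyl on the carbon opposite the ring oxygen gives a 1.3-fold lower number from compound 2 to compound 3 (0.10 log units; within the scatter), so no difference between these two groups can be read at this position. Against the unsubstituted carbon, the same group gives an at least 3.1-fold lower number from compound 1 to compound 3 (0.49 log units; beyond the scatter), which points the same way as the step to ethyl: both substituted compounds, compound 2 and compound 3, stand apart from compound 1. The true size of both steps stays open-ended, since compound 1 sits at a limit of the assay and not at a number: the limit of > 100000 nM in this assay, at which 1 of the 3 values shown sits.

Still open, from the compounds shown here alone, is whether an amine, a carboxylic acid or a longer chain on this carbon would shift the number beyond the scatter. Also open, going by these compounds, is what the fluorine and the hydroxyl each contribute within 3-fluoro-4-hydroxyphenyl.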